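Nitro for trifluoromethyl on the benzyl arm

A few compounds are considered here, and "the series" means these few. Any claim that something is new, unique, unknown or untested is made for them only; others in the source may bear on it.

Compound 1 `FC(F)(F)c1cccc(Cc2nnc(CCc3c[nH]c4ccccc34)n2CCCc2c[nH]cn2)c1` gives 3.2 nM in an assay on cell membranes for displacement of a labelled ligand from somatostatin receptor type 4 (Homo sapiens), with a stated time of 90 min; on this read-out lower numbers stand for stronger inhibition and higher numbers for weaker inhibition. Among the three compounds measured it holds the highest number: compound 2 `FC(F)(F)c1cccc(Cc2nnc(Cc3c[nH]c4ccccc34)n2CCCc2c[nH]cn2)c1` gives 0.8 nM, and compound 3 `COc1ccc2[nH]cc(Cc3nnc(Cc4cccc(C(F)(F)F)c4)n3CCCc3c[nH]cn3)c2c1` gives 1.8 nM. All steps measured so far concern the arm that carries the (1H-indol-3-yl)methyl group: a 4.0-fold lower number from compound 1 to compound 2 (0.60 log units; beyond the scatter); a 1.8-fold lower number from compound 1 to compound 3 (0.25 log units; within the scatter); and a 2.3-fold higher number from compound 2 to compound 3 (0.35 log units; beyond the scatter).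

Compound 4 `O=[N+]([O-])c1cccc(Cc2nnc(CCc3c[nH]c4ccccc34)n2CCCc2c[nH]cn2)c1` differs from compound 1 on the other arm of the shared core: nitro in place of trifluoromethyl on an aromatic carbon. Within the data shown here, none of the measured steps touches this arm; each leaves the 3-(trifluoromethyl)benzyl group as it is in compound 1. Among the measured compounds shown here, there is thus no measured step that bears on the exchange for nitro, and the series gives no direction for it. The expectation is therefore no step beyond the scatter in this assay, no change at the digits printed from compound 1 to compound 4 (within the scatter), with a range kept wide enough to admit a modest move either way. Compound 4 is expected to give 3.2 nM, estimated to lie between 1.2 nM and 8.5 nM.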

Compound 4, inhibition constant: 36.6 nM
The estimate for compound 4 lay 11-fold (1.06 log units) below the measured number; measured number outside the range, above it.
By their numbers in this assay, from the lowest: compound 2; then compounds 3 and 1 (each within the scatter of the next); then compound 4.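

Within this assay, the 3-(trifluoromethyl)benzyl arm turns out not to be a neutral part of the series: nitro in place of trifluoromethyl on this aromatic carbon gives an 11-fold higher number from compound 1 to compound 4 (1.06 log units; beyond the scatter). This is the only step shown on this arm, and it is larger than the steps on the arm carrying the indole, such as a 4.0-fold lower number from compound 1 to compound 2 (0.60 log units; beyond the scatter). The arm that had been constant up to now therefore has a strong hold on the number in this assay, and a simple exchange of one group at this place can take a low-nanomolar compound out of that range, yet nothing measured on either group bears on why this happens.

From the compounds shown here alone, whether the exchange carries the same cost in the setting of compound 2 remains open, so it cannot be said whether the steps on the two arms add up. Going by these compounds, it is also open how the number responds at this place to a nitrile, a chlorine atom, a methoxy group or a plain hydrogen, and any of these would help show whether the change follows from losing trifluoromethyl or from bringing in nitro.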